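This account rests on a few compounds, and the source may have more. Where it says the series, first, only, none or still open, it means among the compounds named here.

Measured so far in an ADME assay on MDBK cells (Bos taurus) for cytotoxicity, read by MTT assay, with a stated time of 96 h; a lower number here means that less compound is tolerated, a higher number that more compound is tolerated: compound 1 `CCC(=O)Nc1ccc(-c2nc3cc(C(F)(F)F)ccc3n2C2CCCCC2)cc1` gives 18000 nM; compound 2 `Oc1ccc(-c2nc3cc(C(F)(F)F)ccc3[nH]2)cc1` gives 51000 nM; compound 3 `O=C(O)CCC(=O)Nc1ccc(-c2nc3cc(C(F)(F)F)ccc3[nH]2)cc1` gives > 100000 nM, which is a limit of the assay and not a number.

Compound 3 therefore stands at the limit of > 100000 nM in this assay, at which 1 of the 3 values shown sits, so only a floor is known for it. Compound 4 `CCC(=O)Nc1ccc(-c2nc3cc(C(F)(F)F)ccc3[nH]2)cc1` differs from compound 3 by hydrogen in place of carboxy on a saturated chain carbon, two bonds along the chain from a carbonyl carbon. Among the compounds with values here, the one measured step touching compound 3, an at least 1.9-fold higher number from compound 2 to compound 3 (0.29 log units; that floor lies within the scatter), does not test removal of the carboxy, and no other pair here does. Compound 1, which also carries a propanoylamino group, gives 18000 nM. Compound 4 is expected near 60000 nM, between 25000 nM and 150000 nM. The expected step of an at least 1.6-fold lower number from compound 3 to compound 4 (0.22 log units; that floor lies within the scatter) is thus modest, with a fair chance that compound 4 again reaches only a limit.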

Compound 4, half-maximal cytotoxic concentration: > 100000 nM
Compound 4 was reported as a limit (the forecaster's own chance of this, stated with the estimate: 35%); at least 1.6-fold (0.22 log units) between middle value and limit.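

The step from compound 3 to compound 4 cannot be read, as both compounds stand at a limit of the assay: the limit of > 100000 nM in this assay, at which 2 of the 4 values shown sit.

Hydrogen in place of cyclohexyl on an aromatic nitrogen gives an at least 5.5-fold higher number from compound 1 to compound 4 (0.74 log units; beyond the scatter), the first step in this assay that clears the scatter. Propanoylamino in place of hydroxy on an aromatic carbon gives an at least 1.9-fold higher number from compound 2 to compound 4 (0.29 log units; that floor lies within the scatter), a floor that fixes no order.

From the compounds shown here alone, whether removing the carboxy changes anything remains open. So does where a methyl in place of the cyclohexyl, or an amine in place of the propanoylamino group, would fall in this assay.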